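Notes on the series: alkyl against hydroxyethoxy side chains

The source may report more compounds than this note shows. Statements on the series, on what has been measured and on what is new or still open speak of the compounds shown alone.

Compound 2 `CN1CCN(c2nc3ccccc3n2CCOCCO)CC1` gives 42 nM in a functional assay on ileum for inhibition of histamine H1 receptor (Cavia porcellus) (on this read-out higher numbers stand for weaker inhibition and lower numbers for stronger inhibition), and stands at the lowest of the two numbers measured; the nearest measured compound is compound 1 `CCCCCCCCCCn1c(N2CCN(C)CC2)nc2ccccc21`, which gives 4200 nM in this assay. Within the data shown here, the one measured step, a 100-fold lower number from compound 1 to compound 2 (2.00 log units; beyond the scatter), replaces an alkyl chain with a hydroxyethoxy-bearing chain on the saturated chain carbon at the aromatic nitrogen.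

Compound 3 `CCCC(C)Cn1c(N2CCN(C)CC2)nc2ccccc21` is not yet measured. Its difference from compound 2 is 1-methylbutyl in place of (2-hydroxyethoxy)methyl on a saturated chain carbon bound to an aromatic nitrogen, that is, the oxygen-bearing chain of compound 2 gives way to a plain branched alkyl chain. Among the measured compounds shown here, this runs in the opposite sense to the step from compound 1 to compound 2, which is the only measured step that bears on it, and that step was large. The expectation is therefore a step upward in this assay for compound 3 that lies beyond the scatter, of about a 14-fold higher number from compound 2 to compound 3 (1.15 log units; beyond the scatter). Because compound 1 gives 4200 nM with a chain longer than the chain entering compound 3, the number expected for compound 3 need not reach that of compound 1. The estimate for compound 3 is 600 nM, with a range from 150 nM to 3000 nM.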

Compound 3, half-maximal inhibitory concentration: 500 nM
For compound 3 the middle estimate is 1.2-fold (0.08 log units) above the measured one; the range from low to high includes it.
By their numbers in this assay, from the lowest: compound 2; then compound 3; then compound 1.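

The earlier step changed chain length and oxygen content together, whereas this one holds the count at 5 heavy atoms on both sides: in this assay, the change to 1-methylbutyl from (2-hydroxyethoxy)methyl gives a 12-fold higher number from compound 2 to compound 3 (1.08 log units; beyond the scatter). A large step therefore appears at this position even with no difference in heavy-atom count, so the gap between the two side-chain types in the first step does not depend on a longer chain. The printed numbers also place the branched chain in the middle, with compound 2 at 42 nM, compound 3 at 500 nM and compound 1 at 4200 nM, so among these three, the all-carbon chains both give higher numbers than the chain bearing oxygen, and neither goes against that order.

This change swaps the ether oxygen, the terminal hydroxyl and the branch all at once, so the compounds shown do not separate them; a 2-methoxyethyl chain would bear on the hydroxyl and an unbranched hexyl chain on the branch. No measurement at hand accounts for the size of the step.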